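A few compounds are considered here, and "the series" means these few. Any claim that something is new, unique, unknown or untested is made for them only; others in the source may bear on it.

Compound 1 `CCC(C)(C)Cc1c[nH]c(CCc2ccc(-c3cnccn3)cc2)n1` is one of three compounds tested in a functional assay on HEK293 cells for agonist activity at Bombesin receptor subtype-3 (Homo sapiens), read by luminescence and calcium flux, with a stated time of 10 min (a lower number here means that less compound is needed, a higher number that more compound is needed for the effect), where compound 1 gives 431 nM. That is the second highest number of the three. Compound 2 `CCC(C)(C)Cc1c[nH]c(CCc2ccc(N3CCCCC3)cc2)n1` gives 171 nM, a change of a 2.5-fold lower number from compound 1 to compound 2 (0.40 log units; beyond the scatter). Compound 3 `CCC(C)(C)Cc1c[nH]c(CCc2ccc(-c3cccnc3C(=O)O)cc2)n1` gives 1260 nM, a change of a 2.9-fold higher number from compound 1 to compound 3 (0.47 log units; beyond the scatter); between those two neighbours the step is a 7.4-fold higher number from compound 2 to compound 3 (0.87 log units; beyond the scatter). Compound 4 `CCC(C)(C)Cc1c[nH]c(CCc2ccc(-c3ccns3)cc2)n1` differs from compound 1 in one place: 1,2-thiazol-5-yl in place of pyrazin-2-yl on an aromatic carbon. Both earlier steps swap the same group at the same place, one giving a modest gain and one a modest loss, so they set the likely size but not the direction. A step of a 1.1-fold lower number from compound 1 to compound 4 (0.03 log units; within the scatter) in this assay is expected, within the scatter. Compound 4 is therefore estimated at 400 nM, with a range from 150 nM to 1100 nM.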

Compound 4, half-maximal effective concentration: 63 nM
Compound 4: middle estimate off by 6.3-fold (0.80 log units), on the high side; the whole stated range lies above it.
By their numbers in this assay, from the lowest: compound 4; then compound 2; then compound 1; then compound 3.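

In this assay the 1,2-thiazol-5-yl ring on this aromatic carbon gives a 6.8-fold lower number from compound 1 to compound 4 (0.84 log units; beyond the scatter) and also a 2.7-fold lower number from compound 2 to compound 4 (0.43 log units; beyond the scatter) and so places an aromatic ring, not piperidin-1-yl, at the lowest number. Within the data shown here, the step of a 20-fold lower number from compound 3 to compound 4 (1.30 log units; beyond the scatter) is the first large one at this position. Pyrazin-2-yl and 1,2-thiazol-5-yl have equal counts of hydrogen-bond donors and acceptors, so those counts do not separate them.

No measurement shown explains the gain. As far as these compounds go, whether the sulfur or the five-membered ring matters stays open, and a thiophene or a 1,3-thiazol-5-yl ring would help separate the two.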